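The compounds below may be only part of what the source reports. "The series", "measured", "known", "first", "only" and "open" are said of these compounds alone.

Of the compounds shown here, three built on a shared core have been measured in a physicochemical assay for solubility, read by HPLC, with a stated time of 24 h, at pH 7.4, tested at 250 uM; a higher number here means a more soluble compound, a lower number a less soluble compound. Compound 1 `CN1CCN(CCCNc2nc(-c3ccccn3)nc3c2CN(Cc2ccccc2)CC3)CC1` gives 180000 nM, compound 2 `CN1CCN(CCCNc2nc(-c3cccnc3)nc3c2CN(Cc2ccccc2)CC3)CC1` gives 234000 nM, and compound 3 `CN(C)CCN1CCN(c2nc(-c3cccnc3)nc3c2CN(Cc2ccccc2)CC3)CC1` gives 247000 nM. Both steps that touch compound 2 lie within the scatter of repeated measurements, so it cannot be separated from either of those two neighbours.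

Compound 4 `CN1CCN(CCCNc2nc(-c3ccncc3)nc3c2CN(Cc2ccccc2)CC3)CC1` has not yet been measured. It has pyridin-4-yl in place of the pyridin-3-yl of compound 2, on an aromatic carbon between two ring nitrogen atoms: pyridin-4-yl in place of pyridin-3-yl on an aromatic carbon. Going by the values given here, the nearest precedent is the other swap of this kind, pyridin-3-yl in place of pyridin-2-yl, which gave a 1.3-fold higher number from compound 1 to compound 2 (0.11 log units; within the scatter). The change of side chain gave a 1.1-fold higher number from compound 2 to compound 3 (0.02 log units; within the scatter). Neither measured step exceeds the scatter, so no step beyond the scatter is expected in this assay, and no direction can be called. The estimated step is a 1.1-fold lower number from compound 2 to compound 4 (0.04 log units; within the scatter). For compound 4 the expected value is 215000 nM, with an estimated range from 150000 nM to 255000 nM.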

Compound 4, solubility: 250000 nM
Estimate against measurement, compound 4: 1.2-fold (0.07 log units) below; the range from low to high includes it.
By their numbers in this assay, from the lowest: compounds 1, 2, 3 and 4 (each within the scatter of the next).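

With compound 4 in hand, all three pyridinyl attachments at this aromatic carbon between two ring nitrogen atoms can be compared in this assay. Pyridin-4-yl in place of pyridin-3-yl gives a 1.1-fold higher number from compound 2 to compound 4 (0.03 log units; within the scatter), and pyridin-4-yl in place of pyridin-2-yl gives a 1.4-fold higher number from compound 1 to compound 4 (0.14 log units; within the scatter); so with the (3-(4-methylpiperazin-1-yl)propyl)amino group held fixed, every placement of the ring nitrogen stays within the scatter of the others, which the single earlier swap could not show. No measurement on hand offers an explanation for this result.

The compounds shown leave open whether a ring of another kind at this carbon, such as a phenyl ring or a pyridinyl ring carrying a carboxylic acid, would give a step beyond the scatter. They also leave open what a simple primary amine in place of the side chain would do.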